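Methoxy Removal at Two Places and Antiproliferative Potency

The source may hold more compounds than are shown below. What is called first, only, known or untested is meant among the compounds shown, and "the series" means these compounds.

Three of the four compounds have been measured in a functional assay on A549 cells (Homo sapiens) for antiproliferative activity, read by MTT assay, with a stated time of 12 h; a higher number here means a weaker inhibitor, a lower number a stronger inhibitor. Compound 1 `COc1cc(OC)c2c(=O)cc(/C=C/c3ccccc3)oc2c1` gives 21500 nM in this assay. Compound 3 `COc1ccc(/C=C/c2cc(=O)c3c(OC)cc(OC)cc3o2)cc1` reaches only the limit of this assay, reported as > 40000 nM. Compound 2 `COc1cccc2oc(/C=C/c3ccc(OC(F)(F)F)cc3)cc(=O)c12` likewise reaches only the limit of this assay, reported as > 40000 nM. The fourth compound, compound 4 `O=c1cc(/C=C/c2ccc(OC(F)(F)F)cc2)oc2ccccc12`, has not yet been measured in this assay.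

Compound 1 arises from compound 3 by hydrogen in place of methoxy on an aromatic carbon. That change gives an at least 1.8-fold lower number from compound 3 to compound 1 (0.26 log units; that floor lies within the scatter). The difference between the cores of compound 2 and compound 3 is not broken down here. Compound 4 arises from compound 2 by hydrogen in place of methoxy on an aromatic carbon. Going by the values given here, this is the same kind of change as the one from compound 3 to compound 1, but not the same: in the first case the place is para to a large group on a ring of carbon only, whereas in the second it is part of a fused or bridged system of two rings, ortho to a fused ring and meta to a fused ring.

The expectation for compound 4 rests on two facts: the step measured from compound 3 to compound 1, an at least 1.8-fold lower number from compound 3 to compound 1 (0.26 log units; that floor lies within the scatter), lies within the scatter, and compound 2 sits at the limit of > 40000 nM in this assay, at which 2 of the 3 values shown sit. Compound 4 is therefore expected to lie close to its parent, with an estimated step of an at least 1.1-fold lower number from compound 2 to compound 4 (0.05 log units; that floor lies within the scatter) in this assay. In this assay compound 4 is estimated at 35000 nM, with a range expected from 15000 nM to 80000 nM.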

Compound 4, half-maximal inhibitory concentration: 15600 nM
Estimate against measurement, compound 4: 2.2-fold (0.35 log units) above, and the stated range covers the measured number.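

In this assay, hydrogen in place of methoxy on an aromatic carbon gives an at least 2.5-fold lower number from compound 2 to compound 4 (0.40 log units; beyond the scatter), a step that can be read as a real lowering of the number on this core. Set beside the earlier case, at a different place on a different core, the two steps compare as follows: the same change on two cores in this assay, an at least 1.8-fold lower number (0.26 log units; that floor lies within the scatter) from compound 3 to compound 1 and an at least 2.5-fold lower number (0.40 log units; beyond the scatter) from compound 2 to compound 4; the limit leaves it open whether they differ Within these four compounds, the change therefore lowers the number beyond the scatter on one core and points the same way on the other, but neither step has a fixed size and the series does not show that the effect carries over by a constant amount, since each step starts from a parent held at a limit: the limit of > 40000 nM in this assay, at which 2 of the 4 values shown sit.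

The compounds shown leave open what other groups would do at the place on an aromatic carbon of the fused system that methoxy leaves in compound 4, for instance a hydroxyl, a fluorine or an amine in place of the hydrogen. Going by these compounds alone, they also leave open how much of the result belongs to the trifluoromethoxy group on the other ring, as no pair here changes that group alone.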